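This account rests on a few compounds, and the source may have more. Where it says the series, first, only, none or still open, it means among the compounds named here.

Three compounds have been measured in a functional assay on A-375 cells (Homo sapiens) for antiproliferative activity, read by MTT assay, with a stated time of 72 h; on this read-out lower numbers stand for stronger inhibition and higher numbers for weaker inhibition:

Compound 1 `COc1ncc(-c2ccc3c(c2)NC(=O)CO3)cc1NS(=O)(=O)c1ccc(F)cc1`: 26300 nM
Compound 2 `COc1ccc(N2C(=O)COc3ccc(-c4cnc(Cl)c(NS(=O)(=O)c5ccc(F)cc5)c4)cc32)cc1`: 32700 nM
Compound 3 `Cc1ccc(N2C(=O)COc3ccc(-c4cnc5ccccc5c4)cc32)cc1`: > 40000 nM (a limit)

Compound 3 reports > 40000 nM, which is a limit of the assay and not a number. Compound 2 gives 32700 nM, within the scatter of compound 1 at 26300 nM, so these two numbers stand level.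

Compound 4 `O=C1COc2ccc(-c3cnc(Cl)c(NS(=O)(=O)c4ccc(F)cc4)c3)cc2N1c1ccc(Cl)cc1` departs from compound 2 by chloro in place of methoxy on an aromatic carbon, turning 4-methoxyphenyl into 4-chlorophenyl. Among the compounds with values here, no measured pair shows this change, so no shift beyond the scatter is expected in this assay. The expected change is a 1.3-fold lower number from compound 2 to compound 4 (0.12 log units; within the scatter). For compound 4 the estimated value is 25000 nM, with an expected range of 10000 nM to 40000 nM.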

Compound 4, half-maximal inhibitory concentration: 30600 nM
The estimate for compound 4 lay 1.2-fold (0.09 log units) below the measured number; the measured number falls inside the stated range.
By their numbers in this assay, from the lowest: compounds 1, 4 and 2 (each within the scatter of the next). At a limit, above all of these: compound 3.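

In this assay, replacing methoxy with chloro gives a 1.1-fold lower number from compound 2 to compound 4 (0.03 log units; within the scatter), the only step shown between compounds that differ in one place. On this aromatic carbon, para to a large group, 4-methoxyphenyl and 4-chlorophenyl therefore stand level, so this exchange does not separate the two compounds. The room left for higher numbers on this read-out is bounded: the limit of > 40000 nM in this assay, at which 1 of the 4 values shown sits.

On these data alone, whether an amine or a carboxylic acid at this position would move the number beyond the scatter remains open. So does whether the exchange of methoxy for chloro would stay level on another core.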